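Chloro for amino on a purine core against lung cancer cells

The compounds below may be only part of what the source reports. "The series", "measured", "known", "first", "only" and "open" are said of these compounds alone.

Measured so far:
compound 1 `Nc1nc(Cl)c2ncn(Cc3ccccc3CCl)c2n1` — 53700 nM
compound 2 `ClCc1ccccc1Cn1cnc2nc(Cl)nc(Cl)c21` — 5750 nM
compound 3 `ClCc1ccc(Cn2cnc3c(Cl)nc(Cl)nc32)cc1` — 37200 nM

Of the compounds shown here, three have been tested in a functional assay on A549 cells (Homo sapiens) for cytotoxicity, read by sulforhodamine B assay, with a stated time of 48 h; on this read-out higher numbers stand for weaker inhibition of growth and lower numbers for stronger inhibition of growth. Compound 1 gives 53700 nM, the highest of the three numbers. Compound 3 sits closest to it, with 37200 nM, a gap that lies within the usual scatter, so no order between compound 1 and compound 3 can be read from these two values. Compound 2 gives 5750 nM, a number clearly separated from that of compound 1, beyond the scatter.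

The next compound is compound 4 `ClCc1ccccc1Cn1cnc2c(Cl)nc(Cl)nc21`, which is derived from compound 1 by one change: chloro in place of amino on an aromatic carbon. Going by the values given here, no measured pair in the set shows this same change, so the size of the step has to be judged from the other dichloro compounds. Compound 2 and compound 3 both carry chloro at this position, and their numbers in this assay lie at or below that of compound 1. The account therefore expects a step downward from compound 1 to compound 4, beyond the scatter, of about a 2.7-fold lower number from compound 1 to compound 4 (0.43 log units; beyond the scatter). Compound 4 is estimated at 20000 nM, with a likely range from 6000 nM to 50000 nM.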

Compound 4, concentration for total growth inhibition: 4670 nM
For compound 4 the middle estimate is 4.3-fold (0.63 log units) above the measured one; measured number outside the range, below it.
By their numbers in this assay, from the lowest: compounds 4 and 2 (each within the scatter of the next); then compounds 3 and 1 (each within the scatter of the next).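

Amino to chloro on the aromatic carbon between two ring nitrogen atoms gives in this assay a large change, an 11-fold lower number from compound 1 to compound 4 (1.06 log units; beyond the scatter) and this is the first single change in the set whose size can be read. The group at this position therefore has a strong bearing on the number for growth inhibition, and the step is far from a small adjustment. Nothing measured here accounts for the size of this step.

From the compounds shown here alone, whether the step comes from gaining chloro or from losing amino stays open, as only these two groups are seen at this position; a methoxy group, a methylamino group or a plain hydrogen there would help to separate the two. Going by these compounds, whether the same change would give a step of similar size on the core of compound 3 also remains open.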